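The compounds below may be only part of what the source reports. "The series", "measured", "known", "first", "only" and "open" are said of these compounds alone.

Three compounds of this series carry numbers in a functional assay on L1210 cells (Mus musculus) for inhibition; on this read-out higher numbers stand for weaker inhibition and lower numbers for stronger inhibition. Compound 1 `COc1cccc(/C=C2\Cc3ccccc3C2=O)c1OC` gives 214000 nM, compound 2 `O=C1/C(=C/c2ccccc2Br)CCCc2ccccc21` gives 37000 nM, and compound 3 `Cc1ccccc1/C=C1\CCc2ccccc2C1=O` gives 50200 nM. Compound 2 holds the lowest of the three numbers, but compound 3 sits within the scatter of it, and only compound 1 lies clearly beyond it.

Compound 4 `O=C1/C(=C/c2ccccc2F)CCCc2ccccc21` differs from compound 2 by fluoro in place of bromo on an aromatic carbon. Within the data shown here, no measured pair in the set shows this change, so its size is not known here. Expected is a small step from compound 2 toward a higher number, of the size a 1.5-fold higher number from compound 2 to compound 4 (0.17 log units; within the scatter), or none beyond the scatter. Compound 4 is estimated at 55000 nM in this assay, within a range of 20000 nM to 150000 nM.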

Compound 4, half-maximal inhibitory concentration: 60400 nM
For compound 4 the middle estimate is 1.1-fold (0.04 log units) below the measured one; low and high end bracket the measured number.
By their numbers in this assay, from the lowest: compounds 2, 3 and 4 (each within the scatter of the next); then compound 1.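

Among these compounds, the first measured pair for this change gives, in this assay, a 1.6-fold higher number from compound 2 to compound 4 (0.21 log units; within the scatter) for fluoro in place of bromo on an aromatic carbon, ortho to a large group. At this place, on this core, the read-out therefore does not separate the two substituents. Nothing at hand accounts for the step.

Going by these compounds, it remains open whether an amine or a carboxylic acid at this place would move the number beyond the scatter. Also open, on these data alone, is whether the exchange behaves alike on the core of compound 1.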